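The source may report more compounds than this note shows. Statements on the series, on what has been measured and on what is new or still open speak of the compounds shown alone.

Compound 1 `CC(C)C(=O)N1CCN(c2cc(NCCN)c3ccccc3n2)CC1` and compound 2 `NCC(O)CNc1cc(N2CCC(c3ccccc3)CC2)nc2ccccc12` are the two measured compounds here. In an ADME assay on HEp-2 cells (Homo sapiens) for cytotoxicity, read by CCK-8 assay, with a stated time of 6 days (a higher number here means that more compound is tolerated, a lower number that less compound is tolerated), compound 1 sits at the limit of > 100000 nM in this assay, at which 1 of the 2 values shown sits, a limit of the assay rather than a number, reported as > 100000 nM. In this assay compound 2 gives 20800 nM. Compound 3 `NCCNc1cc(N2CCN(C(=O)CCc3ccccc3)CC2)nc2ccccc12` differs from compound 1 by phenethyl in place of isopropyl on a carbonyl carbon. Going by the values given here, no measured pair shows a change of this kind, so in this assay only a modest step is expected, if any, in the direction of less compound tolerated. Compound 3 is estimated at 60000 nM, between 15000 nM and 150000 nM, an expected step of an at least 1.6-fold lower number from compound 1 to compound 3 (0.22 log units; that floor lies within the scatter).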

Compound 3, half-maximal cytotoxic concentration: > 100000 nM
Compound 3 was reported as a limit; the forecaster's own chance of this, stated with the estimate: 40%; middle value at least 1.6-fold (0.22 log units) away from the limit.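

Compound 1 and compound 3 both give a limit of the assay rather than a number in this assay, so no step between them can be read: the limit of > 100000 nM in this assay, at which 2 of the 3 values shown sit.

Going by these compounds, whether phenethyl in place of isopropyl on a carbonyl carbon changes how much compound is tolerated, and by how much, stays open.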